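Methyl on Selenium: a Single Step from Compound 1

The source may report more compounds than this note shows. Statements on the series, on what has been measured and on what is new or still open speak of the compounds shown alone.

For the measured compounds named here, compound 1 `Nc1nc([SeH])nc2ncccc12` is the only member of this small set that carries a number. In a functional assay on CCRF-CEM cells (Homo sapiens) for cytotoxicity, read by MTT assay, with a stated time of 72 h (a lower number here means a stronger inhibitor of growth, a higher number a weaker inhibitor of growth), compound 1 gives 61500 nM. Compound 2 `[SeH]c1nc([SeH])c2cccnc2n1` belongs to the same set, but in this assay compound 2 gives "not determined" (no result reported), so compound 1 stands alone on the numbers shown and can be ranked against nothing else. Compound 3 `C[Se]c1nc(N)c2cccnc2n1` differs from compound 1 in one place: methyl in place of hydrogen on a selenium. Going by the values given here, no step between two measured compounds covers this change, so there is no measured precedent in this assay for it. With a single value to build on, any expectation has to be cautious and wide. The step from compound 1 to compound 3 is expected to be small, hardly beyond the usual scatter, leaning if anything toward weaker growth inhibition, and is estimated at a 1.3-fold higher number from compound 1 to compound 3 (0.11 log units; within the scatter). Compound 3 is therefore estimated at 80000 nM in this assay, with a range from 25000 nM to 250000 nM, and there is a fair chance that the assay reports only a limit rather than a number.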

Compound 3, concentration for total growth inhibition: > 100000 nM
Compound 3: no number, only a limit; the forecaster's own chance of this, stated with the estimate: 25%; at least 1.2-fold (0.09 log units) between middle value and limit.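

For the compounds shown here, with compound 3, the change of methyl in place of hydrogen on a selenium can be read for the first time in this assay, and what it gives is a floor rather than a size: the step is an at least 1.6-fold higher number from compound 1 to compound 3 (0.21 log units; that floor lies within the scatter). Compound 3 gives > 100000 nM, which is a limit of the assay and not a number. The step therefore shows no shift beyond the usual scatter, yet it does not rule out a much larger one, and its true size stays unread because the result for compound 3 sits at the edge of what the assay reports: the limit of > 100000 nM in this assay, at which 1 of the 3 values shown sits.

The compounds shown leave open whether anything placed on this selenium other than methyl, such as an ethyl group, a longer chain or a chain ending in a carboxylic acid, would give a number rather than a limit in this assay. Going by these compounds alone, they also leave open what the amine on the shared core contributes, since the only compound that carries a different group there has no reported result in this assay.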